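Removing the phenol and methoxy groups from compound 3

The source may hold more compounds than are shown below. What is called first, only, known or untested is meant among the compounds shown, and "the series" means these compounds.

Of the compounds shown here, three with a shared core have been measured in an ADME assay on microsomes from liver (Mus musculus) for metabolic stability, read by LC-MS, with a stated time of 1 h, tested at 5 uM; a lower number here means that less of the compound is left, a higher number that more of the compound is left. Compound 1 `Cc1cc(C)cc(N2CCN(C(=O)c3oc(C)nc3-c3ccccc3)CC2)c1` gives 12%, and compound 2 `COc1cc(OC)cc(N2CCN(C(=O)c3oc(C)nc3-c3ccccc3)CC2)c1` gives 0.7%. These two differ only at the amine nitrogen in the ring, and the step of a number 11.3 percentage points lower from compound 1 to compound 2 (beyond the scatter) shows that the change there lowered the remaining fraction by a modest amount. Compound 3 `COc1cc(-c2nc(C)oc2C(=O)N2CCN(c3cccc(Cl)c3)CC2)ccc1O` gives 72.5%, the highest of the three numbers; its lead over compound 1 and over compound 2 is beyond the scatter in both cases.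

Compound 4 `Cc1nc(-c2ccccc2)c(C(=O)N2CCN(c3cccc(Cl)c3)CC2)o1` is the compound not yet measured. It differs from compound 3 in one place: phenyl in place of 4-hydroxy-3-methoxyphenyl on an aromatic carbon. Going by the values given here, no measured step covers this change directly. Among the compounds with values here, what the data do show is that compound 1 and compound 2, which both carry phenyl at this same position, sit far below compound 3, even though they differ from compound 4 at the amine nitrogen in the ring, where the only known step was modest. The expectation is therefore a sizeable drop, estimated as a number 52.5 percentage points lower from compound 3 to compound 4 (beyond the scatter). Compound 4 is expected to give about 20%, within a range from 3% to 50%.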

Compound 4, percent of the compound remaining: 2%
Compound 4: middle estimate off by 18 percentage points, on the high side, outside the stated range (below it).
By their numbers in this assay, from the lowest: compounds 2, 4 and 1 (each within the scatter of the next, the first and the last beyond it); then compound 3.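

Going by these compounds alone, with the 3-chlorophenyl on the amine nitrogen held fixed, placing phenyl on this aromatic carbon instead of 4-hydroxy-3-methoxyphenyl gives, in this assay, a number 70.5 percentage points lower from compound 3 to compound 4 (beyond the scatter) and so ties a large step to this one place, something the earlier compounds, which differed from compound 3 in two places, could not do. The group on the amine nitrogen, by contrast, shows no step beyond the scatter once phenyl sits on the aromatic carbon: 3-chlorophenyl gives a number 1.3 percentage points higher from compound 2 to compound 4 (within the scatter) when it replaces 3,5-dimethoxyphenyl and a number 10 percentage points lower from compound 1 to compound 4 (within the scatter) when it replaces 3,5-dimethylphenyl, so the high number of compound 3 does not come from 3-chlorophenyl alone. Nothing measured here explains why the exchange on the aromatic carbon has so large an effect.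

The compounds shown do not separate the hydroxy group from the methoxy group, so a 4-hydroxyphenyl or a 3-methoxyphenyl at this place would be needed to tell which of them, or whether only the pair, goes with the higher number. As far as these compounds go, it also remains open whether 4-hydroxy-3-methoxyphenyl gives a similar step alongside 3,5-dimethylphenyl or 3,5-dimethoxyphenyl on the amine nitrogen.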